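Cinnamamide series on HT-29: fluoro for methoxy

The source may hold more compounds than are shown below. What is called first, only, known or untested is meant among the compounds shown, and "the series" means these compounds.

Measured compounds:
compound 1 `COc1cccc(/C=C/C(=O)Nc2cc(C(=O)c3cc(OC)c(OC)c(OC)c3)ccc2OC)c1` gives 1900 nM in a functional assay on HT-29 cells (Homo sapiens) for cytotoxicity, read by MTT assay, with a stated time of 72 h; a lower number here means a stronger inhibitor, a higher number a weaker inhibitor
compound 2 `C#CCOc1cccc(/C=C/C(=O)Nc2cc(C(=O)c3cc(OC)c(OC)c(OC)c3)ccc2OC)c1` gives 7400 nM in this assay
compound 3 `COc1cc(/C=C/C(=O)Nc2cc(C(=O)c3cc(OC)c(OC)c(OC)c3)ccc2OC)ccc1F` gives 7700 nM in this assay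

Compound 3 stands highest of the three numbers, within the scatter of compound 2 (a 1.0-fold higher number from compound 2 to compound 3 (0.02 log units; within the scatter)) and beyond it only against compound 1 (a 4.1-fold higher number from compound 1 to compound 3 (0.61 log units; beyond the scatter)). Compound 4 `COc1ccc(C(=O)c2cc(OC)c(OC)c(OC)c2)cc1NC(=O)/C=C/c1ccc(F)c(F)c1` differs from compound 3 thus: fluoro in place of methoxy on an aromatic carbon. Among the compounds with values here, no measured step swaps methoxy for fluoro. The nearest hints are a 4.1-fold higher number from compound 1 to compound 3 (0.61 log units; beyond the scatter), where a fluoro entered on the same ring, and a 3.9-fold higher number from compound 1 to compound 2 (0.59 log units; beyond the scatter), where the methoxy was altered; both gave modest weakening. A modest step toward a higher number, or none beyond the scatter, is therefore expected in this assay, as a 1.3-fold higher number from compound 3 to compound 4 (0.11 log units; within the scatter). Compound 4 is estimated at 10000 nM, range 4000 nM to 25000 nM.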

Compound 4, half-maximal inhibitory concentration: 4200 nM
For compound 4 the middle estimate is 2.4-fold (0.38 log units) above the measured one; low and high end bracket the measured number.
By their numbers in this assay, from the lowest: compound 1; then compounds 4, 2 and 3 (each within the scatter of the next).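

In this assay fluoro in place of methoxy on this aromatic carbon, ortho to a fluoro group, gives a 1.8-fold lower number from compound 3 to compound 4 (0.26 log units; within the scatter) and so shows that this position can lose the methoxy without a step beyond the scatter. The 3,4-difluorophenyl group likewise gives a 1.8-fold lower number from compound 2 to compound 4 (0.25 log units; within the scatter) against 3-(propargyloxy)phenyl, but a 2.2-fold higher number from compound 1 to compound 4 (0.34 log units; beyond the scatter) against 3-methoxyphenyl, which leaves compound 1 apart from the other three. Nothing measured here accounts for these steps. As far as these compounds go, whether a hydroxyl or an amine on this carbon, with the neighbouring fluoro kept, would return the number toward that of compound 1 stays open.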